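A few compounds are considered here, and "the series" means these few. Any claim that something is new, unique, unknown or untested is made for them only; others in the source may bear on it.

For the measured compounds named here, compound 2 `CN(Cc1cc(C(F)(F)F)cc(C(F)(F)F)c1)C(=O)c1c(N2CCCC2)c2ccccc2n(C)c1=O` gives 1100 nM in an assay for inhibition of phosphatidylcholine:ceramide cholinephosphotransferase 2 (Mus musculus), read by mass spectrometry, with stated times of 60 min and 30 min (a higher number here means a weaker inhibitor, a lower number a stronger inhibitor), the highest of the two numbers at hand; the only other measured compound, compound 1 `CC(C)CCOc1c(C(=O)N(C)Cc2cc(C(F)(F)F)cc(C(F)(F)F)c2)c(=O)n(C)c2ccccc12`, gives 260 nM. Going by the values given here, the single measured step, a 4.2-fold higher number from compound 1 to compound 2 (0.63 log units; beyond the scatter), corresponds to pyrrolidin-1-yl in place of isopentyloxy on an aromatic carbon. Compound 3 `CN(Cc1cc(C(F)(F)F)cc(C(F)(F)F)c1)C(=O)c1c(OCCCC2CCCCC2)c2ccccc2n(C)c1=O` has not yet been measured; it differs from compound 2 by 3-cyclohexylpropoxy in place of pyrrolidin-1-yl on an aromatic carbon. This change runs the opposite way to the measured step, returning from pyrrolidin-1-yl to an alkoxy group as in compound 1, although the 3-cyclohexylpropoxy chain entering is not the same as the isopentyloxy of compound 1. Because the step of a 4.2-fold higher number from compound 1 to compound 2 (0.63 log units; beyond the scatter) was modest but beyond the scatter, a move of roughly that size back toward a lower number is expected, a 3.9-fold lower number from compound 2 to compound 3 (0.59 log units; beyond the scatter). Compound 3 is therefore estimated to give about 280 nM in this assay, within a range of 90 nM to 900 nM.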

Compound 3, half-maximal inhibitory concentration: 190 nM
For compound 3 the middle estimate is 1.5-fold (0.17 log units) above the measured one; the range from low to high includes it.
By their numbers in this assay, from the lowest: compounds 3 and 1 (each within the scatter of the next); then compound 2.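

In this assay, the position opposite the ring nitrogen responds to a return from pyrrolidin-1-yl to an alkoxy chain, with a 5.8-fold lower number from compound 2 to compound 3 (0.76 log units; beyond the scatter) as the step. A second alkoxy comparison, a 1.4-fold lower number from compound 1 to compound 3 (0.14 log units; within the scatter), shows that the two chains cannot be told apart here, so cyclohexylmethyl in place of isopropyl at the chain end has no readable effect. No evidence bearing on the cause of either step is at hand.

As far as these compounds go, the step from compound 2 to compound 3 changes both the linking atom and the group attached to it, so the share of each remains open; a 3-cyclohexylpropylamino chain would separate the two. Also open, from the compounds shown here alone, is how far this position tolerates other chain ends, such as a phenyl ring, a carboxylic acid or an amine.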